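The source may report more compounds than this note shows. Statements on the series, on what has been measured and on what is new or still open speak of the compounds shown alone.

Measured compounds:
- compound 1, `COC(=O)/C=C/c1cccc(N(Cc2ccc(/C=C/c3cccc(F)c3)cc2)C(=O)C(C)C)c1`, 71 nM
- compound 2, `COC(=O)/C=C/c1cccc(N(Cc2ccc(/C=C/c3ccccn3)cc2)C(=O)C2CCCCC2)c1`, 309 nM
- compound 3, `COC(=O)/C=C/c1cccc(N(Cc2ccc(/C=C/c3ccccn3)cc2)C(=O)C(C)C)c1`, 310 nM

In an assay on isolated protein with Bile acid receptor (Homo sapiens) as the target (a lower number here means that less compound is needed, a higher number that more compound is needed for the effect), compound 3 gives the highest number of the three. Its nearest neighbour is compound 2, from which it differs only at the carbonyl group: a 1.0-fold higher number from compound 2 to compound 3 (0.00 log units; within the scatter). Compound 1 lies furthest away: a 4.4-fold higher number from compound 1 to compound 3 (0.64 log units; beyond the scatter), where a pyridin-2-yl ring took the place of a 3-fluorophenyl ring.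

Compound 4, `COC(=O)/C=C/c1cccc(N(Cc2ccc(-c3ccc(C)cc3)cc2)C(=O)C(C)C)c1`, has not been measured. It differs from compound 3 in one place: 4-methylphenyl in place of 2-(pyridin-2-yl)ethenyl on an aromatic carbon. Within the data shown here, only the step from compound 1 to compound 3 touches this region, and it shows that exchanging a carbon-only aromatic ring for the pyridin-2-yl ring raised the number modestly. Going back to a carbon-only ring in compound 4 may therefore lower the number again, but the double bond outside the aromatic rings is also removed, and no measured pair tests that. The expected step is a 2.1-fold lower number from compound 3 to compound 4 (0.32 log units; beyond the scatter), a modest fall with wide uncertainty. Compound 4 is estimated at 150 nM, within 40 nM to 600 nM.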

Compound 4, half-maximal effective concentration: 118 nM
For compound 4 the middle estimate is 1.3-fold (0.10 log units) above the measured one, and the stated range covers the measured number.
By their numbers in this assay, from the lowest: compounds 1 and 4 (each within the scatter of the next); then compounds 2 and 3 (each within the scatter of the next).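

In this assay, the aromatic carbon of the shared core can carry a ring attached directly, without the double bond, and activity is kept: 4-methylphenyl in place of 2-(pyridin-2-yl)ethenyl gives a clear change (a 2.6-fold lower number from compound 3 to compound 4 (0.42 log units; beyond the scatter)). Against 2-(3-fluorophenyl)ethenyl, the same exchange stays within the usual scatter (a 1.7-fold higher number from compound 1 to compound 4 (0.22 log units; within the scatter)), so among these three compounds only the pyridin-2-yl group stands apart, while the two carbon-only groups cannot be told apart. Nothing available here explains why these groups compare as they do.

Among these compounds, no pair separates the removal of the double bond from the change of ring, since both change together in each step. From the compounds shown here alone, how an amine on the 4-methylphenyl ring, or a carboxylic acid in place of the methyl ester, would read in this assay also remains open.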